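The source may report more compounds than this note shows. Statements on the series, on what has been measured and on what is new or still open speak of the compounds shown alone.

Among the compounds with values here, compound 2 `Cc1ccc(NC(=O)Nc2ccc(Oc3ccc(-c4ncc[nH]4)cc3)cc2)cc1` stands lowest of the two numbers so far in a functional assay on A549 cells (Homo sapiens) for inhibition, read by MTT assay and WST assay, with a stated time of 72 h, tested at 10 uM; a lower number here means less inhibition of growth, a higher number more inhibition of growth at the concentration tested: compound 2 gives 24.6%. Compound 1 `O=C(Nc1ccc(Oc2ccc(-c3nccs3)cc2)cc1)Nc1cc(C(F)(F)F)ccc1Cl` differs from compound 2 at two places, the aryl on the urea nitrogen and the heteroaromatic ring at the other end, and in this assay compound 1 gives 75.5%, a gap beyond the usual scatter. Two changes at once leave open which of them carries the gap. Compound 3 `O=C(Nc1ccc(Oc2ccc(-c3ncc[nH]3)cc2)cc1)Nc1cc(C(F)(F)F)ccc1Cl` differs from compound 2 in one place only: 2-chloro-5-(trifluoromethyl)phenyl in place of 4-methylphenyl on an amide-type nitrogen. This brings in the aryl of compound 1 with the rest of compound 2 unchanged. Within the data shown here, no measured pair differing in one place exists, so the size of the step is open. A rise is expected because compound 1 with the same aryl gives 75.5%. The expected step is a number 35.4 percentage points higher from compound 2 to compound 3 (beyond the scatter). Compound 3 is estimated at 60% in this assay, within a range of 35% to 82%.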

Compound 3, percent growth inhibition at one concentration: 22.3%
For compound 3 the middle estimate is 37.7 percentage points above the measured one; measured number outside the range, below it.
By their numbers in this assay, from the lowest: compounds 3 and 2 (each within the scatter of the next); then compound 1.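

In this assay the exchange on the amide-type nitrogen gives a number 2.3 percentage points lower from compound 2 to compound 3 (within the scatter) with 1H-imidazol-2-yl at the other end, so with that ring in place the 4-methylphenyl and 2-chloro-5-(trifluoromethyl)phenyl compounds read alike. Within the data shown here, with 2-chloro-5-(trifluoromethyl)phenyl held fixed, 1H-imidazol-2-yl in place of 1,3-thiazol-2-yl on an aromatic carbon gives a number 53.2 percentage points lower from compound 1 to compound 3 (beyond the scatter) and is the only one of the two steps beyond the scatter, so the gap first seen between compound 1 and compound 2 now sits with the heteroaromatic ring. Nothing available gives a reason for either step.

From the compounds shown here alone, whether the aryl exchange on the amide-type nitrogen also reads flat with 1,3-thiazol-2-yl in place remains open. Also open, going by these compounds, is where a 1,3-oxazol-2-yl ring on that aromatic carbon would fall relative to compound 1 and compound 3.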